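Extending the Ester Chain: From Compound 2 to Compound 3

The compounds below may be only part of what the source reports. "The series", "measured", "known", "first", "only" and "open" are said of these compounds alone.

Compound 1 `CCCCCCOC(=O)CCC(=O)N1CCN(CCCOc2cc3c(Nc4ccc(F)c(Cl)c4)ncnc3cc2OC)CC1`: 63.6%
Compound 2 `CCCCCCCCCCCCCCOC(=O)CCC(=O)N1CCN(CCCOc2cc3c(Nc4ccc(F)c(Cl)c4)ncnc3cc2OC)CC1`: 84.9%

In a functional assay on A549 cells (Homo sapiens) for cytotoxicity, read by MTT assay, with a stated time of 24 h, tested at 60 uM (a lower number here means a stronger effect, a higher number a weaker effect of the compound at the concentration tested), compound 1 gives 63.6%, while compound 2 gives 84.9%. Of the two numbers, compound 2 stands highest, which here means the weaker effect at the concentration tested; the gap to compound 1 lies beyond the scatter.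

Compound 3 `CCCCCCCCCCCCCCCCOC(=O)CCC(=O)N1CCN(CCCOc2cc3c(Nc4ccc(F)c(Cl)c4)ncnc3cc2OC)CC1` differs from compound 2 by ethyl in place of hydrogen on a saturated chain carbon, ten or more bonds along the chain from an oxygen next to a carbonyl group. Among the measured compounds shown here, the only measured step that bears on this is a number 21.3 percentage points higher from compound 1 to compound 2 (beyond the scatter), and it was a modest rise for the same kind of alteration, carried out at an earlier point of that chain. A further rise, smaller than before because compound 2 already gives 84.9%, is therefore expected for compound 3, as a number 5.1 percentage points higher from compound 2 to compound 3 (within the scatter). The value of compound 3 is estimated at 90%, with a range from 76% to 100%.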

Compound 3, a percentage reported as activity, at one concentration (the size of the read-out at that concentration, not a potency): 80%
Compound 3: the middle estimate sits 10 percentage points above what was measured, within the range that was stated.
By their numbers in this assay, from the lowest: compound 1; then compounds 3 and 2 (each within the scatter of the next).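

In this assay, ethyl in place of hydrogen this far along the ester chain gives a number 4.9 percentage points lower from compound 2 to compound 3 (within the scatter), so the earlier rise is not seen to continue at this position and compound 2 and compound 3 cannot be told apart. Decyl in place of hydrogen on the shorter chain of compound 1 gives a number 16.4 percentage points higher from compound 1 to compound 3 (beyond the scatter), which shows that compound 3, like compound 2, keeps a weaker effect than compound 1 at the concentration tested. Nothing available explains this result.

The compounds shown leave open where between the chain of compound 1 and that of compound 2 the number changes, and whether a still longer chain would stay in the same range. They also leave open what an amine or a carboxylic acid at the far end of the chain would do.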